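Thiosemicarbazones with varied aryl groups against melanoma cells

This account rests on a few compounds, and the source may have more. Where it says the series, first, only, none or still open, it means among the compounds named here.

Measured so far:
compound 1 `CC1=CC[C@@H]([C@@](C)(O)CCCC(C)(C)NC(=S)N/N=C\c2ccccc2)CC1`: 43800 nM
compound 2 `COc1ccc(/C=N\NC(=S)NC(C)(C)CCC[C@](C)(O)[C@@H]2CC=C(C)CC2)cc1`: 22100 nM

Compound 1 `CC1=CC[C@@H]([C@@](C)(O)CCCC(C)(C)NC(=S)N/N=C\c2ccccc2)CC1` gives 43800 nM in a functional assay on UACC-62 cells (Homo sapiens) for cytotoxicity, read by sulforhodamine B assay; on this read-out higher numbers stand for weaker inhibition of growth and lower numbers for stronger inhibition of growth. Compound 2 `COc1ccc(/C=N\NC(=S)NC(C)(C)CCC[C@](C)(O)[C@@H]2CC=C(C)CC2)cc1` gives 22100 nM in this assay. Compound 2 has the lower of the two numbers, but the step of a 2.0-fold lower number from compound 1 to compound 2 (0.30 log units; within the scatter) lies within the scatter, so the two values cannot be told apart.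

Compound 3 `CC1=CC[C@@H]([C@@](C)(O)CCCC(C)(C)NC(=S)N/N=C\c2ccccc2[N+](=O)[O-])CC1` differs from compound 2 by 2-nitrophenyl in place of 4-methoxyphenyl on a carbon with a double bond to nitrogen. Within the data shown here, no measured step covers this exchange. Among the measured compounds shown here, the only step seen, a 2.0-fold lower number from compound 1 to compound 2 (0.30 log units; within the scatter), shows that changing a substituent on the aromatic ring attached to the imine carbon moved the number by less than the scatter. On these data alone, on that basis no step beyond the scatter is expected in this assay from compound 2 to compound 3, and the wide range reflects that the new group is untested. Compound 3 is estimated at 30000 nM in this assay, with a range from 10000 nM to 90000 nM. The expected step of a 1.4-fold higher number from compound 2 to compound 3 (0.13 log units; within the scatter) is therefore small.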

Compound 3, concentration for total growth inhibition: 16600 nM
Estimate against measurement, compound 3: 1.8-fold (0.26 log units) above, within the range that was stated.
By their numbers in this assay, from the lowest: compounds 3, 2 and 1 (each within the scatter of the next, the first and the last beyond it).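

In this assay, among these compounds, the 2-nitrophenyl group on the carbon with a double bond to nitrogen gives the first step in this set that lies beyond the scatter, a modest one (a 2.6-fold lower number from compound 1 to compound 3 (0.42 log units; beyond the scatter)) with nitro in place of hydrogen on an aromatic carbon. Its exchange for 4-methoxyphenyl stays within the scatter (a 1.3-fold lower number from compound 2 to compound 3 (0.12 log units; within the scatter)), so these two substituted aryl groups cannot be told apart at this position, and only compound 3 separates from compound 1. No evidence at hand bears on what lies behind these steps.

The compounds shown leave open whether 4-nitrophenyl would behave like 2-nitrophenyl at this position. They also leave open whether an aryl group carrying an amine or a carboxylic acid would give a larger step from compound 1 in this assay.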